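The source may hold more compounds than are shown below. What is called first, only, known or untested is meant among the compounds shown, and "the series" means these compounds.

For the measured compounds named here, in a functional assay on A2780 cells (Homo sapiens) for antiproliferative activity, read by CellTiter-Glo, with a stated time of 4 days (on this read-out lower numbers stand for stronger inhibition and higher numbers for weaker inhibition), compound 1 (`CCC(=O)N[C@@H](C)c1ccc(NC(=O)[C@H]2C[C@@H]2c2cccnc2)cc1`) gives 5 nM, the lower of the two numbers measured so far, while compound 2 (`CCC(=O)NC(C)(C)c1ccc(NC(=O)[C@H]2C[C@@H]2c2cccnc2)cc1`) gives 832 nM. Compound 3 (`C[C@H](NC(=O)C1CCOCC1)c1ccc(NC(=O)[C@H]2C[C@@H]2c2cccnc2)cc1`) keeps the core of compound 1 and alters one group: oxan-4-yl in place of ethyl on a carbonyl carbon. Put simply, oxan-4-yl stands in place of ethyl on a carbonyl carbon. Going by the values given here, the only measured step is a 170-fold higher number from compound 1 to compound 2 (2.22 log units; beyond the scatter). That large step shows how far one change to compound 1 can move the number, but it sits at a different place, on an aromatic carbon. Among the compounds with values here, no measured pair tests a change on the carbonyl carbon, so its size cannot be carried over. A modest step toward a higher number in this assay is expected, with wide uncertainty. The expected step is a 2.4-fold higher number from compound 1 to compound 3 (0.38 log units; beyond the scatter). For compound 3 the estimated value is 12 nM, within an expected range of 3 nM to 60 nM.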

Compound 3, half-maximal inhibitory concentration: 3 nM
Beside the measured number, compound 3's estimate is 4.0-fold (0.60 log units) above it, and the stated range covers the measured number.
By their numbers in this assay, from the lowest: compounds 3 and 1 (each within the scatter of the next); then compound 2.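

In this assay, oxan-4-yl in place of ethyl on the carbonyl carbon gives a 1.7-fold lower number from compound 1 to compound 3 (0.22 log units; within the scatter), so this read-out does not separate the two compounds. For the compounds shown here, this is the first measured change at this place, and it shows that a group with more heavy atoms, a six-membered non-aromatic ring and a hydrogen-bond acceptor can replace ethyl here without a step beyond the scatter. No measured evidence is available to explain this result.

Going by these compounds alone, with only this one pair at this place, the separate parts played by the ring and its oxygen remain open, and cyclohexyl, the same ring with carbon in place of oxygen, would address that question. Going by these compounds, how an amine, such as piperidin-4-yl, or a carboxylic acid on the same carbonyl carbon would read also remains open.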